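Amide aryl variation: pyridin-2-yl to thiophen-3-yl

The source may hold more compounds than are shown below. What is called first, only, known or untested is meant among the compounds shown, and "the series" means these compounds.

The series shares the core of compound 1 `O=C(Nc1cc(-c2ccccc2)nn1-c1ccccc1)c1cccc(Cl)c1` and varies the group on the carbonyl carbon. In an assay on CHO cells with metabotropic glutamate receptor 5 (Homo sapiens) as the target (on this read-out higher numbers stand for an effect only at larger amounts of compound and lower numbers for an effect already at smaller amounts), compound 1 gives 40 nM, compound 2 `O=C(Nc1cc(-c2ccccc2)nn1-c1ccccc1)c1ccccn1` gives 290 nM and compound 3 `O=C(Nc1cc(-c2ccccc2)nn1-c1ccccc1)c1ccccc1F` gives 75 nM. Compound 2 stands highest of the three numbers; the steps of a 3.9-fold lower number from compound 2 to compound 3 (0.59 log units; beyond the scatter) and a 7.3-fold higher number from compound 1 to compound 2 (0.86 log units; beyond the scatter) both lie beyond the scatter. Compound 4 `O=C(Nc1cc(-c2ccccc2)nn1-c1ccccc1)c1ccsc1` differs from compound 2 by thiophen-3-yl in place of pyridin-2-yl on a carbonyl carbon. Both measured steps bear on this change, since compound 1 and compound 3 each give a lower number than compound 2 and the entering thiophen-3-yl likewise carries no nitrogen. A modest lowering is therefore expected for compound 4 in this assay, about a 3.6-fold lower number from compound 2 to compound 4 (0.56 log units; beyond the scatter). The estimate for compound 4 is 80 nM, with a range from 30 nM to 250 nM.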

Compound 4, half-maximal effective concentration: 1800 nM
Estimate against measurement, compound 4: 23-fold (1.35 log units) below; the whole stated range lies below it.
By their numbers in this assay, from the lowest: compounds 1 and 3 (each within the scatter of the next); then compound 2; then compound 4.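

In this assay the step of a 6.2-fold higher number from compound 2 to compound 4 (0.79 log units; beyond the scatter) shows that a ring without nitrogen on the carbonyl carbon does not by itself go with a lower number. Thiophen-3-yl also stands clearly apart from the two substituted phenyl groups, with a 24-fold higher number from compound 3 to compound 4 (1.38 log units; beyond the scatter) and a 45-fold higher number from compound 1 to compound 4 (1.65 log units; beyond the scatter) at the same place. Nothing measured here accounts for these steps.

Open, from the compounds shown here alone, is whether thiophen-2-yl, furan-3-yl or a chlorine-bearing thiophene would follow compound 4 or the substituted phenyl compounds.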